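Swapping an isopropyl ester for a methoxyethyl one

The compounds below may be only part of what the source reports. "The series", "measured", "known", "first", "only" and "open" are said of these compounds alone.

Of the compounds shown here, two have been measured in a functional assay (aorta) with Oryctolagus cuniculus as the target; on this read-out lower numbers stand for stronger inhibition and higher numbers for weaker inhibition. Compound 1, with structure `COCCO/C(O)=C1\C(C)=NC(C)=C(C(=O)OCCCN2C(=O)c3ccccc3S2(=O)=O)C1c1ccccc1[N+](=O)[O-]`, gives 2.7 nM in this assay. Compound 2, with structure `CC1=NC(C)=C(C(=O)OCCCN2C(=O)c3ccccc3S2(=O)=O)C(c2ccccc2Cl)/C1=C(\O)OC(C)C`, gives 1.3 nM and so stands at the lower of the two numbers, with compound 1 the nearest neighbour and its gap to compound 2 beyond the usual scatter. Compound 3, with structure `COCCO/C(O)=C1\C(C)=NC(C)=C(C(=O)OCCCN2C(=O)c3ccccc3S2(=O)=O)C1c1ccccc1Cl`, has not yet been measured. It differs from compound 2 in one place: 2-methoxyethyl in place of isopropyl on an oxygen on an unsaturated carbon. Among the measured compounds shown here, the same 2-methoxyethyl group already appears in compound 1, which carries a different substituent on its phenyl ring, so no clean single step for this exchange exists among the measured compounds. The expectation is a small loss of potency, if any, with the step from compound 2 to compound 3 estimated at a 1.5-fold higher number from compound 2 to compound 3 (0.19 log units; within the scatter). Compound 3 is therefore expected to give about 2 nM in this assay, within a range from 0.7 nM to 6 nM.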

Compound 3, half-maximal inhibitory concentration: 2.9 nM
Estimate against measurement, compound 3: 1.5-fold (0.16 log units) below, and the stated range covers the measured number.
By their numbers in this assay, from the lowest: compound 2; then compounds 1 and 3 (each within the scatter of the next).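

On an oxygen on an unsaturated carbon, 2-methoxyethyl in place of isopropyl gives a 2.2-fold higher number from compound 2 to compound 3 (0.35 log units; beyond the scatter) in this assay, so this position responds to the exchange, though only modestly. Among the compounds shown here, compound 3 also provides the first clean comparison on the aromatic carbon: chloro in place of nitro gives a 1.1-fold higher number from compound 1 to compound 3 (0.03 log units; within the scatter), so with 2-methoxyethyl present, the two numbers cannot be told apart. Nothing measured alongside these compounds explains the loss seen with 2-methoxyethyl.

As far as these compounds go, what remains open is whether the added oxygen or simply the longer chain accounts for that step, a question that a plain butyl group or a 2-hydroxyethyl group on the same oxygen could help answer. From the compounds shown here alone, it is also open whether chloro and nitro would remain indistinguishable with isopropyl on that oxygen.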